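Cytotoxicity in mouse macrophage cells: two measured compounds, one open

A few compounds are considered here, and "the series" means these few. Any claim that something is new, unique, unknown or untested is made for them only; others in the source may bear on it.

Measured so far:
Compound 1, `C=CCO[C@H]1O[C@H](CN)[C@@H](OCc2ccc3ccccc3c2)[C@H](OCc2ccc3ccccc3c2)[C@H]1N`: 86.9%
Compound 2, `CCCCCCCCCO[C@@H]1[C@@H](N)[C@@H](OC[C@@H](O)CN)O[C@H](CN)[C@H]1OCCCCCCCCC`: 85.1%

Of the compounds shown here, two have been tested in a toxicity assay on the whole organism (J774 cells) for cytotoxicity, with Mus musculus as the target, read by MTT assay, with a stated time of 24 h, tested at 10 uM; on this read-out lower numbers stand for a stronger effect and higher numbers for a weaker effect at the one concentration tested. Compound 1 gives 86.9%, the higher of the two numbers, and compound 2 gives 85.1%, a number that lies within the scatter of compound 1, so the two cannot be told apart on this read-out.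

Compound 3, `NC[C@H]1O[C@H](O[C@H]2[C@H](O)[C@@H](O)[C@H](N)C[C@@H]2N)[C@H](N)[C@@H](OCc2ccc3ccccc3c2)[C@@H]1OCc1ccc2ccccc2c1`, has not yet been measured in this assay. It differs from compound 1 in one place: 4,6-diamino-2,3-dihydroxycyclohexyl in place of allyl on an oxygen on a saturated carbon. Among the compounds with values here, no step between measured compounds exists to show what such a change does here. Because compound 1 sits at 86.9% and compound 2 at 85.1%, both weak effects, the step of a number 1.1 percentage points higher from compound 1 to compound 3 (within the scatter) is expected to stay small, with no clear direction beyond the scatter. Compound 3 is therefore estimated at 88%, in the range 74% to 100%.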

Compound 3, a percentage reported as activity, at one concentration (the size of the read-out at that concentration, not a potency): 79.1%
The estimate for compound 3 lay 8.9 percentage points above the measured number; low and high end bracket the measured number.
By their numbers in this assay, from the lowest: compounds 3, 2 and 1 (each within the scatter of the next).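

In this assay, putting 4,6-diamino-2,3-dihydroxycyclohexyl in place of allyl on an oxygen on a saturated carbon gives a number 7.8 percentage points lower from compound 1 to compound 3 (within the scatter). This is the first step shown at this position, and it suggests that, at the one concentration tested, the read-out cannot distinguish a small open chain from a much larger carbon ring bearing amino and hydroxyl groups. Nothing available explains why the step stays within the scatter.

A single step cannot show whether other groups on this oxygen, such as a simple aminoethyl group, a carboxylic acid or a longer alkyl chain, would also stay within the scatter of compound 1. Also open, going by these compounds, is whether the reading for compound 3 would hold at other concentrations.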